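A Mirror-Image Side Chain on the Shared Core

The source may hold more compounds than are shown below. What is called first, only, known or untested is meant among the compounds shown, and "the series" means these compounds.

Compound 1 `CC(C)(C)Sc1c(CC(C)(C)C(=O)O)n(Cc2ccc(Cl)cc2)c2ccc(CCc3ccc4ccccc4n3)cc12` is the starting point. In a functional assay for inhibition, with Homo sapiens as the target (on this read-out lower numbers stand for stronger inhibition and higher numbers for weaker inhibition), compound 1 gives 4 nM, the top of the two numbers shown, though the gap to compound 3 `C[C@@H](COc1ccc2c(c1)c(SC(C)(C)C)c(CC(C)(C)C(=O)O)n2Cc1ccc(Cl)cc1)c1ccccn1`, which gives 2 nM, is only a 2.0-fold lower number from compound 1 to compound 3 (0.30 log units; within the scatter). Compound 2 `CC(C)(C)Sc1c(CC(C)(C)C(=O)O)n(Cc2ccc(Cl)cc2)c2ccc(OCc3nc4ccccc4o3)cc12` is reported as a limit of the assay, < 7 nM. Compound 4 `C[C@H](COc1ccc2c(c1)c(SC(C)(C)C)c(CC(C)(C)C(=O)O)n2Cc1ccc(Cl)cc1)c1ccccn1` carries the change (a group of 10 heavy atoms (8 carbon, 1 nitrogen, 1 oxygen; one six-membered aromatic ring with 1 hetero atom) in place of a group of 12 heavy atoms (11 carbon, 1 nitrogen; one six-membered aromatic ring of carbon only, one six-membered aromatic ring with 1 hetero atom), on an aromatic carbon), and its entering group differs from that of compound 3 only in its defined stereocentre. The steps a step that the limit leaves unreadable from compound 1 to compound 2 and a step that the limit leaves unreadable from compound 2 to compound 3 cannot be sized. Compound 4 is therefore expected to stay close to compound 1, with the step of no change at the digits printed from compound 1 to compound 4 (within the scatter). For compound 4 the estimate is 4 nM, expected to fall between 1.5 nM and 12 nM.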

Compound 4, half-maximal inhibitory concentration: 3 nM
For compound 4 the middle estimate is 1.3-fold (0.12 log units) above the measured one; measured number inside the range.
By their numbers in this assay, from the lowest: compounds 3, 4 and 1 (each within the scatter of the next).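

At this aromatic carbon, the new pyridine-bearing side chain stands in for 2-(quinolin-2-yl)ethyl with a 1.3-fold lower number from compound 1 to compound 4 (0.12 log units; within the scatter). The other form of its stereocentre gives a 1.5-fold higher number from compound 3 to compound 4 (0.18 log units; within the scatter), so this assay does not separate the two forms, and this comparison isolates the stereocentre alone: the fact that compounds 3 and 4 differ only in the configuration as drawn

As far as these compounds go, the step from compound 2 to compound 4 cannot be read, since compound 2 is reported only as a limit: the limit of < 7 nM in this assay, at which 1 of the 4 values shown sits. Whether a side chain ending in an amine instead of the pyridine ring would read the same remains open.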